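This account rests on a few compounds, and the source may have more. Where it says the series, first, only, none or still open, it means among the compounds named here.

Of the compounds shown here, three have been measured in a functional assay on B16-F10 cells (Mus musculus) for antiproliferative activity, read by MTT assay, with a stated time of 48 h; a lower number here means a stronger inhibitor, a higher number a weaker inhibitor. Compound 1 `CCOc1ccc(C(=O)/C=C/c2c(/C=C/c3ccc(OC)cc3)cc(OC)cc2OC)cc1` gives 6.4 ug/mL. Compound 2 `COc1ccc(/C=C/c2cc(OC)cc(OC)c2/C=C/C(=O)c2ccc(N)cc2)cc1` gives 2.8 ug/mL, and compound 3 `COc1ccc(/C=C/c2cc(OC)cc(OC)c2/C=C/C(=O)c2cccc(Cl)c2)cc1` gives 3.3 ug/mL. Compound 3 thus holds the second highest of the three numbers, yet both steps leading to it, a 1.2-fold higher number from compound 2 to compound 3 (0.07 log units; within the scatter) and a 1.9-fold lower number from compound 1 to compound 3 (0.29 log units; within the scatter), lie inside the scatter, so it cannot be told apart from either neighbour. Compound 4 `COc1ccc(/C=C/c2cc(OC)cc(OC)c2/C=C/C(=O)c2ccc(OC)cc2)cc1` differs from compound 3 in one place: 4-methoxyphenyl in place of 3-chlorophenyl on a carbonyl carbon. Two measured steps also exchanged the ring on the carbonyl carbon, and both stayed inside the scatter: a 1.9-fold lower number from compound 1 to compound 3 (0.29 log units; within the scatter) and a 1.2-fold higher number from compound 2 to compound 3 (0.07 log units; within the scatter). Among the measured compounds shown here, the only step beyond the scatter, a 2.3-fold lower number from compound 1 to compound 2 (0.36 log units; beyond the scatter), exchanged a single group on that ring and was still modest. Exchanging the ring on the carbonyl carbon has so far not moved the number beyond the scatter, so no step beyond the scatter is expected for compound 4 in this assay. Compound 4 is estimated at 4.5 ug/mL, with a range from 2 ug/mL to 10 ug/mL. This amounts to an expected 1.4-fold higher number from compound 3 to compound 4 (0.13 log units; within the scatter).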

Compound 4, half-maximal inhibitory concentration: 5.8 ug/mL
For compound 4 the middle estimate is 1.3-fold (0.11 log units) below the measured one; the range from low to high includes it.
By their numbers in this assay, from the lowest: compounds 2, 3, 4 and 1 (each within the scatter of the next, the first and the last beyond it).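

In this assay, 4-methoxyphenyl in place of 3-chlorophenyl on the carbonyl carbon gives a 1.8-fold higher number from compound 3 to compound 4 (0.24 log units; within the scatter), so a third exchange of this ring stays inside the scatter. Within the ring's single-group changes, going from ethoxy to methoxy gives a 1.1-fold lower number from compound 1 to compound 4 (0.04 log units; within the scatter), which does not separate the two groups, while methoxy in place of amino gives a 2.1-fold higher number from compound 2 to compound 4 (0.32 log units; beyond the scatter), a modest step beyond the scatter. Amino thus stands apart from both ethoxy and methoxy, although compound 3, with its 3-chlorophenyl, remains within the scatter of all three.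

Nothing available explains why amino stands apart. The compounds shown leave open whether a hydroxyl or a dimethylamino group on that ring would fall with amino or with ethoxy and methoxy.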